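Swapping the benzyl group in a phenyl-substituted imide series

A few compounds are considered here, and "the series" means these few. Any claim that something is new, unique, unknown or untested is made for them only; others in the source may bear on it.

Compound 2 `COc1ccccc1CN1C(=O)c2c(C)nc(-c3nc(C)no3)c(N)c2C1=O` and compound 1 `Cc1noc(-c2nc(C)c3c(c2N)C(=O)N(Cc2cccc(C(F)(F)F)c2)C3=O)n1` share one core and differ only in the group on a saturated chain carbon bound to an amide-type nitrogen in a ring. In a physicochemical assay for solubility, using the shake flask method, in simulated intestinal fluid, measured as kinetic solubility, with a stated time of 2 h, at 25 degrees C, at pH 6.5 (a lower number here means a less soluble compound, a higher number a more soluble compound), compound 1 gives < 5000 nM, a limit of the assay. In this assay compound 2 gives < 5000 nM, likewise a limit. The step that the two limits leave unreadable from compound 1 to compound 2 is therefore unreadable, as the limit of < 5000 nM in this assay, at which 2 of the 2 values shown sit, shows. Compound 3 `Cc1noc(-c2nc(C)c3c(c2N)C(=O)N(Cc2ccc(CO)cc2)C3=O)n1` differs from compound 2 by 4-(hydroxymethyl)phenyl in place of 2-methoxyphenyl on a saturated chain carbon bound to an amide-type nitrogen in a ring. For the measured compounds named here, no measured step bears on this change, so no direction can be read from the measured compounds. The step expected here is estimated as an at least 1.2-fold higher number from compound 2 to compound 3 (0.07 log units; that floor lies within the scatter), staying near the limit. Compound 3 is estimated at 6000 nM, within 1500 nM to 25000 nM.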

Compound 3, solubility: < 5000 nM
Compound 3: a limit, no number; the forecaster's own chance of this, stated with the estimate: 50%; middle value at least 1.2-fold (0.07 log units) from the limit.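

In this assay, for the compounds shown here, compound 3 gives only a limit, so no step from compound 1 or compound 2 to compound 3 can be read: the limit of < 5000 nM in this assay, at which 3 of the 3 values shown sit. On these data alone, whether compound 1, compound 2 and compound 3 differ at all in this assay stays open.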